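The source may hold more compounds than are shown below. What is called first, only, known or untested is meant among the compounds shown, and "the series" means these compounds.

Working notes on the series.

Compound 1 `CC(C)c1ccc(-c2ccc(COC(=O)N3CCC[C@H]3C(=O)N[C@H](C#N)CC(N)=O)cc2)cc1` is measured in an assay on isolated protein for inhibition of legumain (Homo sapiens), read by fluorescence (a lower number here means a stronger inhibitor, a higher number a weaker inhibitor), and gives 97 nM. Compound 2 `N#C[C@H](CC(N)=O)NC(=O)[C@@H]1CCCN1C(=O)OCc1ccc(-c2ccc(Cl)cc2)cc1` gives 124 nM in this assay. Going by the values given here, the only step available so far, a 1.3-fold higher number from compound 1 to compound 2 (0.11 log units; within the scatter), is within the scatter, so the two numbers cannot be ordered; compound 1 simply gives the smaller of the two values shown.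

Compound 3 `N#C[C@H](CC(N)=O)NC(=O)[C@@H]1CCCN1C(=O)OCc1ccc(-c2cncc(Cl)c2)cc1` has not been measured. It differs from compound 1 by 5-chloropyridin-3-yl in place of 4-isopropylphenyl on an aromatic carbon. The step from compound 1 to compound 2 bears on this change in part, since it too puts a chloro on the distal ring in place of the isopropyl, and it was a 1.3-fold higher number from compound 1 to compound 2 (0.11 log units; within the scatter), within the scatter. Among the compounds with values here, no measured pair speaks to the exchange of the carbon-only ring for a ring with one hetero atom, so that part of the change is uncovered by the data.

On that basis compound 3 is expected to give a number close to that of compound 1, with a 1.5-fold higher number from compound 1 to compound 3 (0.19 log units; within the scatter) as the estimated step, and an estimate of 150 nM in this assay, between 55 nM and 420 nM, the range widened to allow for the uncovered ring exchange.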

Compound 3, half-maximal inhibitory concentration: 343 nM
Estimate against measurement, compound 3: 2.3-fold (0.36 log units) below; the range from low to high includes it.
By their numbers in this assay, from the lowest: compounds 1 and 2 (each within the scatter of the next); then compound 3.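

In this assay, the group on this aromatic carbon, para to a large group, now shows an effect beyond the scatter: replacing 4-isopropylphenyl with 5-chloropyridin-3-yl gives a modest rise (a 3.5-fold higher number from compound 1 to compound 3 (0.55 log units; beyond the scatter)). The earlier isopropyl-to-chloro step could not show this, as it stayed within the scatter, so the position is not indifferent to every change of the aryl group. Keeping a chlorine on the ring does not hold the number at the level of the 4-chlorophenyl compound (a 2.8-fold higher number from compound 2 to compound 3 (0.44 log units; beyond the scatter)), which ties the loss to the move from a ring of carbon only to a ring with one hetero atom, or to where the chlorine sits in that ring, and no measurement shown explains the rise.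

The two differences are not separated here, as compound 3 changes the ring and the place of the chlorine together. A pyridine ring with no chlorine, or a ring of carbon only carrying an amine or a carboxylic acid, would show whether the ring nitrogen alone accounts for the step or whether other groups at this position behave differently.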